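Series notes: the step from compound 3 to compound 4

This account rests on a few compounds, and the source may have more. Where it says the series, first, only, none or still open, it means among the compounds named here.

The compounds share one core and differ on a saturated chain carbon bound to a double-bonded ring carbon. In a functional assay on SMMC-7721 cells (Homo sapiens) for antiproliferative activity, read by MTT assay, with a stated time of 48 h (a lower number here means a stronger inhibitor, a higher number a weaker inhibitor), the chloro member compound 1 `CC(C)=CCC[C@]1(C)/C=C/[C@@H](OC(=O)C=C(C)C)[C@](C)(O)/C=C/C(=O)/C(CCl)=C\C1` gives 840 nM. The diisopropylamino member compound 2 `CC(C)=CCC[C@]1(C)/C=C/[C@@H](OC(=O)C=C(C)C)[C@](C)(O)/C=C/C(=O)/C(CN(C(C)C)C(C)C)=C\C1` gives 340 nM. Compound 3 `CC(C)=CCC[C@]1(C)/C=C/[C@@H](OC(=O)C=C(C)C)[C@](C)(O)/C=C/C(=O)/C(Cn2cc(CO)nn2)=C\C1`, carrying 4-(hydroxymethyl)-1H-1,2,3-triazol-1-yl, gives 3560 nM, the highest number of the three.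

The change to compound 4 `CSC(=S)OC/C1=C/C[C@](C)(CCC=C(C)C)/C=C/[C@@H](OC(=O)C=C(C)C)[C@](C)(O)/C=C/C1=O` is a group of 5 heavy atoms (2 carbon, 1 oxygen, 2 sulfur; no ring) in place of a group of 7 heavy atoms (3 carbon, 3 nitrogen, 1 oxygen; one five-membered aromatic ring with 3 hetero atoms), on a saturated chain carbon bound to a double-bonded ring carbon. Among the compounds with values here, no measured compound carries the entering group, so only indirect evidence exists. Two steps lead to the triazolyl group: a 4.2-fold higher number from compound 1 to compound 3 (0.63 log units; beyond the scatter) and a 10-fold higher number from compound 2 to compound 3 (1.02 log units; beyond the scatter). Both groups that lack a ring therefore give lower numbers in this assay, and they differ from each other by a 2.5-fold lower number from compound 1 to compound 2 (0.39 log units; beyond the scatter). On that basis, a modest move to a lower number is expected, with the estimated step being a 3.0-fold lower number from compound 3 to compound 4 (0.47 log units; beyond the scatter). For compound 4 the estimated value is 1200 nM, with an expected range of 400 nM to 3500 nM.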

Compound 4, half-maximal inhibitory concentration: 720 nM
Compound 4: the middle estimate sits 1.7-fold (0.22 log units) above what was measured, and the stated range covers the measured number.
By their numbers in this assay, from the lowest: compound 2; then compounds 4 and 1 (each within the scatter of the next); then compound 3.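

In this assay the sulfur-bearing group without a ring gives a 4.9-fold lower number from compound 3 to compound 4 (0.69 log units; beyond the scatter) and so joins chloro and diisopropylamino as a third ring-free group with a lower number than the triazolyl member; no compound shown goes against this split. The same group still gives a 2.1-fold higher number from compound 2 to compound 4 (0.33 log units; beyond the scatter) and cannot be separated from chloro, with a 1.2-fold lower number from compound 1 to compound 4 (0.07 log units; within the scatter), so among the ring-free groups only diisopropylamino stands apart from compound 4. Nothing measured here explains these differences.

Still open, on these data alone, is whether the sulfur atoms of the entering group matter, which a methyl carbonate on the same carbon would test. A simple secondary amine such as dimethylamino, or a triazole without its hydroxymethyl group, would show how far the diisopropylamino and triazolyl results extend to related groups.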